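Compound 4: 2-chlorophenyl in place of 4-chlorophenyl

This account rests on a few compounds, and the source may have more. Where it says the series, first, only, none or still open, it means among the compounds named here.

In an ADME assay on microsomes from liver (Rattus norvegicus) for metabolic stability (a lower number here means that the compound disappears faster, a higher number that the compound lasts longer), compound 3 `Nc1nc(NCCNc2ncc(-c3ncc[nH]3)c(-c3ccc(Cl)cc3)n2)ccc1[N+](=O)[O-]` gives > 0.5 h, a limit and not a number. Compound 1 `FC(F)(F)c1ccc(NCCNc2ncc(-c3ncc[nH]3)c(-c3ccc(Cl)cc3Cl)n2)nc1` gives > 0.5 h, also a limit. Compound 2 `Clc1ccc(-c2nc(NCCNc3ccccn3)ncc2-c2ncc[nH]2)c(Cl)c1` gives > 0.5 h, again a limit. The series therefore stands at the limit of > 0.5 h in this assay, at which 3 of the 3 values shown sit.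

Compound 4 `Nc1nc(NCCNc2ncc(-c3ncc[nH]3)c(-c3ccccc3Cl)n2)ccc1[N+](=O)[O-]` has 2-chlorophenyl in place of 4-chlorophenyl on an aromatic carbon. Among the compounds with values here, the one measured step, a step that the two limits leave unreadable from compound 1 to compound 2, is a change of hydrogen in place of trifluoromethyl and gives no size to carry over. No step beyond the scatter is expected in this assay, an expectation that rests on compound 3 with its limit of > 0.5 h. The expected step is a step that the limit leaves unreadable from compound 3 to compound 4. Compound 4 is estimated at 0.8 h, with an expected range of 0.4 h to 2.5 h.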

Compound 4, half-life: > 0.5 h
Compound 4 was reported as a limit (the forecaster's own chance of this, stated with the estimate: 80%); the middle value lies beyond the limit too.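

Compound 3 and compound 4 both stand at a limit in this assay, so no step can be read between them: the limit of > 0.5 h in this assay, at which 4 of the 4 values shown sit.

The compounds shown leave open the actual half-lives in this assay, and whether 2-chlorophenyl and 4-chlorophenyl differ at all.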